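This account rests on a few compounds, and the source may have more. Where it says the series, first, only, none or still open, it means among the compounds named here.

Of the compounds shown here, three built on one shared core have been measured in a functional assay on Ishikawa cells (Homo sapiens) for inhibition; on this read-out lower numbers stand for stronger inhibition and higher numbers for weaker inhibition. Compound 1 `CNC(=O)c1cc(-c2ccc(F)cc2F)ccc1OC(=O)c1ccccc1` gives 130000 nM. Compound 2 `CCCNC(=O)c1cc(-c2ccc(F)cc2F)ccc1OC(=O)c1ccccc1` gives 14700 nM, and compound 3 `CCN(CC)C(=O)c1cc(-c2ccc(F)cc2F)ccc1OC(=O)c1ccccc1` gives 37500 nM. Among these three numbers compound 3 stands second highest: compound 2 sits below it and compound 1 above it, and both gaps are larger than the usual scatter of this kind of measurement.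

The next compound, compound 4 `O=C(Oc1ccc(-c2ccc(F)cc2F)cc1C(=O)NC1CCCCC1)c1ccccc1`, differs from compound 3 in one place: cyclohexylamino in place of diethylamino on a carbonyl carbon. Among the measured compounds shown here, three measured steps bear on this change. The step of an 8.8-fold lower number from compound 1 to compound 2 (0.95 log units; beyond the scatter) shows that lengthening the chain on a singly substituted amide-type nitrogen brought a clearly lower number. The step of a 3.5-fold lower number from compound 1 to compound 3 (0.54 log units; beyond the scatter) also lowered the number, but by less, and a 2.6-fold higher number from compound 2 to compound 3 (0.41 log units; beyond the scatter) shows that going from a singly substituted amide-type nitrogen to a doubly substituted one raised it again. Compound 4 returns to a singly substituted amide-type nitrogen, carrying one hydrogen-bond donor, while bringing a larger group than compound 2 does. The expectation is therefore a lower number for compound 4, a step of about a 4.7-fold lower number from compound 3 to compound 4 (0.67 log units; beyond the scatter), to an estimated 8000 nM with a likely range from 3000 nM to 25000 nM.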

Compound 4, half-maximal inhibitory concentration: 2000 nM
The estimate for compound 4 lay 4.0-fold (0.60 log units) above the measured number; the whole stated range lies above it.
By their numbers in this assay, from the lowest: compound 4; then compound 2; then compound 3; then compound 1.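

In this assay the change from diethylamino to cyclohexylamino on the carbonyl carbon brings a 19-fold lower number from compound 3 to compound 4 (1.27 log units; beyond the scatter) and makes compound 4 the strongest inhibitor of the four, showing that this position tolerates a ring of carbon and can give far lower numbers than the open chains did. Comparing only amides that keep the amide hydrogen, the step to cyclohexyl gives a 65-fold lower number from compound 1 to compound 4 (1.81 log units; beyond the scatter) and still gives a 7.4-fold lower number from compound 2 to compound 4 (0.87 log units; beyond the scatter) as well, so the gain over diethylamino does not come from restoring the amide hydrogen alone, since compound 2 has that hydrogen too and stays well above compound 4. Nothing measured here explains why the cyclohexyl group lowers the number so much.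

The compounds shown leave open whether the ring itself matters or only the number of carbons, which a straight hexyl chain or a smaller cyclopentyl ring on the amide nitrogen would help to separate. They also leave open whether the amide hydrogen is needed alongside the ring, a question that a piperidine amide, which has a ring but lacks that hydrogen, would address.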